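This account rests on a few compounds, and the source may have more. Where it says the series, first, only, none or still open, it means among the compounds named here.

Compound 1 `COc1cc(-c2nn(-c3cccc(NC(=O)c4cccc(C(F)(F)F)c4)c3)cc2-c2ccncc2)ccc1Cl` gives in a functional assay on MOLT-4 cells (Homo sapiens) for inhibition, read by sulforhodamine B assay, with a stated time of 48 h (a higher number here means a weaker inhibitor of growth, a lower number a stronger inhibitor of growth), only a limit, > 50000 nM.
Compound 2 `COc1cc(-c2nn(-c3cccc(NC(=O)Nc4ccc(Cl)c(Cl)c4)c3)cc2-c2ccncc2)ccc1Cl` gives 4480 nM.
Compound 3 `COc1cc(-c2nn(-c3cccc(NC(=O)Nc4cccc(C(F)(F)F)c4)c3)cc2-c2ccncc2)ccc1Cl` gives 3480 nM.

Compound 3 and compound 2 sit within the scatter of each other, a 1.3-fold lower number from compound 2 to compound 3 (0.11 log units; within the scatter), while compound 1 gave only a limit. Compound 4 `COc1cc(-c2nn(-c3cccc(NC(=O)c4ccc(Cl)c(C(F)(F)F)c4)c3)cc2-c2ccncc2)ccc1Cl` differs from compound 3 by 4-chloro-3-(trifluoromethyl)phenyl in place of (3-(trifluoromethyl)phenyl)amino on a carbonyl carbon. For the measured compounds named here, two measured steps bear on this change: an at least 11-fold lower number from compound 1 to compound 2 (1.04 log units; beyond the scatter) and an at least 14-fold lower number from compound 1 to compound 3 (1.15 log units; beyond the scatter). Both put an arylamino group on the carbonyl carbon in place of an aryl group, and both were large. Compound 4 takes the reverse direction, back to an aryl group on the carbonyl carbon as in compound 1. A large rise in the number is therefore expected, an 11-fold higher number from compound 3 to compound 4 (1.06 log units; beyond the scatter). Compound 4 is estimated at 40000 nM, between 8000 nM and 200000 nM, with a fair chance that only a limit is reported, as for compound 1 (the limit of > 50000 nM in this assay, at which 1 of the 3 values shown sits).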

Compound 4, concentration for total growth inhibition: > 32500 nM
Compound 4: a limit, no number; the forecaster's own chance of this, stated with the estimate: 55%; the middle value lies beyond the limit too.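

On this carbonyl carbon, the loss seen with an aryl group in this assay also appears with a different aryl group, 4-chloro-3-(trifluoromethyl)phenyl: an at least 9.3-fold higher number from compound 3 to compound 4 (0.97 log units; beyond the scatter), and an at least 7.2-fold higher number from compound 2 to compound 4 (0.86 log units; beyond the scatter). The group that leaves carries a hydrogen-bond donor and the group that enters carries none, although these compounds cannot show whether that difference matters. Compound 1 and compound 4 both give only limits, and the step between them, chloro in place of hydrogen, cannot be read.

Still open, going by these compounds, is how a methoxy group or a methylamino group on this carbonyl carbon would compare with the arylamino groups of compound 2 and compound 3.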